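The source may hold more compounds than are shown below. What is called first, only, known or untested is meant among the compounds shown, and "the series" means these compounds.

Measured in a functional assay on P388 cells (Mus musculus) for antiproliferative activity, read by colorimetric assay and MTT assay; a higher number here means a weaker inhibitor, a lower number a stronger inhibitor:
- Compound 1 `COc1ccc(S(=O)(=O)Nc2cccc3cc[nH]c23)cc1`: 1.1 ug/mL
- Compound 2 `O=S(=O)(Nc1cccc2cc[nH]c12)c1ccc(Cl)cc1`: 6 ug/mL
- Compound 3 `O=S(=O)(Nc1cccc2cc(O)[nH]c12)c1ccc(Cl)cc1`: 2.2 ug/mL

Compound 2, at 6 ug/mL, has the highest number of the three. Compound 4 `Nc1ccc(S(=O)(=O)Nc2cccc3cc[nH]c23)cc1` departs from it by amino in place of chloro on an aromatic carbon, with amino in place of chloro on an aromatic carbon, para to a large group. The closest evidence is a 5.5-fold higher number from compound 1 to compound 2 (0.74 log units; beyond the scatter), where chloro took the place of methoxy at this same place. Read in reverse, that step favours a lower number once chloro leaves. Among the measured compounds shown here, the other measured change, a 2.7-fold lower number from compound 2 to compound 3 (0.44 log units; beyond the scatter), lies elsewhere on the shared core and bears only loosely, and no amino compound has been measured. A modest step in this assay toward a lower number is therefore expected, estimated as a 3.0-fold lower number from compound 2 to compound 4 (0.48 log units; beyond the scatter). For compound 4 the expected value is 2 ug/mL, with an expected range from 0.7 ug/mL to 6 ug/mL.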

Compound 4, half-maximal inhibitory concentration: 14 ug/mL
Beside the measured number, compound 4's estimate is 7.0-fold (0.85 log units) below it; the whole stated range lies below it.
By their numbers in this assay, from the lowest: compounds 1 and 3 (each within the scatter of the next); then compound 2; then compound 4.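

In this assay, leaving chloro at this place, para to a large group, does not by itself lower the number: amino gives a 2.3-fold higher number from compound 2 to compound 4 (0.37 log units; beyond the scatter). Methoxy and amino also lie far apart, with a 13-fold higher number from compound 1 to compound 4 (1.10 log units; beyond the scatter), so the three groups run methoxy, chloro, amino from the lowest number to the highest. No measurement shown here explains this order. The compounds shown leave open where a dimethylamino group or a carboxylic acid would fall at this place. They also leave open whether the order of these groups would hold with hydroxy in place of hydrogen on the shared core.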